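This account rests on a few compounds, and the source may have more. Where it says the series, first, only, none or still open, it means among the compounds named here.

Measured in an ADME assay (liver) for metabolic stability, with Liver microsome (Homo sapiens) as the target, using microsomes and NADPH, with a stated time of 30 min, tested at 1 uM; on this read-out lower numbers stand for slow clearance and higher numbers for fast clearance:
- compound 1 `CCn1cc(-c2cc(C(O)(C(F)(F)F)C(F)(F)F)cnc2N2CCN(S(=O)(=O)c3ccc(N)nc3)CC2)cn1`: 20 mL.min-1.g-1
- compound 2 `CS(=O)(=O)Nc1cccc(-c2cc(C(O)(C(F)(F)F)C(F)(F)F)cnc2N2CCN(S(=O)(=O)c3ccc(N)nc3)CC2)c1`: 40 mL.min-1.g-1
- compound 3 `Nc1ccc(S(=O)(=O)N2CCN(c3ncc(C(O)(C(F)(F)F)C(F)(F)F)cc3-c3ccncc3)CC2)cn1`: 15 mL.min-1.g-1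

Compound 3 stands at 15 mL.min-1.g-1, which cannot be told apart from compound 1, given a 1.3-fold lower number from compound 1 to compound 3 (0.12 log units; within the scatter). Only compound 2 is clearly separated from it, with a 2.7-fold lower number from compound 2 to compound 3 (0.43 log units; beyond the scatter).

The next compound is compound 4 `Nc1ccc(S(=O)(=O)N2CCN(c3ncc(C(O)(C(F)(F)F)C(F)(F)F)cc3-c3ccc4scnc4c3)CC2)cn1`, with 1,3-benzothiazol-5-yl in place of pyridin-4-yl on an aromatic carbon. All three measured steps are changes at this same carbon, so they are the ones that bear on it. Two stay within the scatter, a 2.0-fold higher number from compound 1 to compound 2 (0.30 log units; within the scatter) and a 1.3-fold lower number from compound 1 to compound 3 (0.12 log units; within the scatter), and the largest, a 2.7-fold lower number from compound 2 to compound 3 (0.43 log units; beyond the scatter), is modest. Among the measured compounds shown here, none of the measured compounds carries 1,3-benzothiazol-5-yl, so these steps guide the size of the change only loosely. Groups at this carbon have so far shifted the number little, and compound 2, at 40 mL.min-1.g-1, shows that a substituent other than pyridin-4-yl can sit higher than compound 3 does. A small upward move is therefore expected, not clearly beyond the scatter. The expected step is a 1.7-fold higher number from compound 3 to compound 4 (0.22 log units; within the scatter). For compound 4 the estimated value is 25 mL.min-1.g-1, with an expected range of 12 mL.min-1.g-1 to 50 mL.min-1.g-1.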

Compound 4, intrinsic clearance in microsomes: 39 mL.min-1.g-1
For compound 4 the middle estimate is 1.6-fold (0.19 log units) below the measured one, and the stated range covers the measured number.
By their numbers in this assay, from the lowest: compounds 3, 1, 4 and 2 (each within the scatter of the next, the first and the last beyond it).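

In this assay, 1,3-benzothiazol-5-yl in place of pyridin-4-yl gives a 2.6-fold higher number from compound 3 to compound 4 (0.41 log units; beyond the scatter) and is the second group at this carbon, after 3-(methanesulfonamido)phenyl, to be separated from pyridin-4-yl beyond the scatter. The two larger groups cannot be told apart, with a 1.0-fold lower number from compound 2 to compound 4 (0.01 log units; within the scatter) despite their different ring systems, and the step to the ethylpyrazole gives no clear separation either, with a 2.0-fold higher number from compound 1 to compound 4 (0.29 log units; within the scatter) for 1,3-benzothiazol-5-yl in place of 1-ethyl-1H-pyrazol-4-yl, so among the four compounds only the pairs that set compound 3 against compound 2 or compound 4 are resolved, and compound 1 is resolved from none. Nothing available here accounts for why pyridin-4-yl and 1,3-benzothiazol-5-yl differ at this carbon.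

Going by these compounds, all four compounds carry an aromatic ring at this carbon, so it remains open how a morpholine, a simple amine or a carboxylic acid would read there. On these data alone, it is also open whether the step between pyridin-4-yl and 1,3-benzothiazol-5-yl keeps its size when the 2,2,2-trifluoro-1-hydroxy-1-(trifluoromethyl)ethyl group is exchanged for another group on the shared core.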